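Three Purine Amides and a Side Chain Removed

This account rests on a few compounds, and the source may have more. Where it says the series, first, only, none or still open, it means among the compounds named here.

The three compounds measured share a core in which a cyclopropyl-bearing nitrogen links a purine to an acetamide that carries an amino acid fragment. Compound 1 `O=C(O)[C@@H]1CCCN1C(=O)CN(c1nc(Cl)nc2[nH]cnc12)C1CC1` gives 31.5% in a functional assay on the whole organism (Tail, strain ICR) with Mus musculus as the target, in the tail flick test, with a stated time of 30 min, at a dose of 25 umol/kg by the oral route; a higher number here means a stronger effect of the compound at the dose given, a lower number a weaker effect. Compound 2 `N=C(N)NCCC[C@H](NC(=O)CN(c1ncnc2c1ncn2C1CCCCO1)C1CC1)C(=O)OCc1ccccc1` gives 34.3% in this assay, and compound 3 `CC(C)C[C@H](NC(=O)CN(c1nc(Cl)nc2[nH]cnc12)C1CC1)C(=O)OCc1ccccc1` gives 33.9% in this assay. Compound 2 holds the highest of the three numbers, but the nearest, compound 3, lies within the scatter of it, and so does the furthest, compound 1; the three values cannot be told apart.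

Compound 4 `O=C(CN(c1ncnc2c1ncn2C1CCCCO1)C1CC1)NCC(=O)OCc1ccccc1` has not been measured in this assay. It differs from compound 2 in one place: a hydrogen atom in place of a group of 7 heavy atoms (4 carbon, 3 nitrogen; no ring), on a saturated chain carbon bound to an amide-type nitrogen and a carbonyl carbon. For the measured compounds named here, no step between measured compounds is available for this change, yet the three measured compounds carry quite different amino acid fragments and give values within the scatter of each other. Compound 4 is therefore expected to fall in the same band, with a step from compound 2 of a number 4.3 percentage points lower from compound 2 to compound 4 (within the scatter) that stays within the scatter. Compound 4 is estimated at 30%, within 15% to 45%.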

Compound 4, a percentage reported as activity, at one dose (the size of the read-out at that dose, not a potency): 55.7%
For compound 4 the middle estimate is 25.7 percentage points below the measured one; the measured number lies above the stated range.
By their numbers in this assay, from the lowest: compounds 1, 3 and 2 (each within the scatter of the next); then compound 4.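

In this assay, for the compounds shown here, the step of a number 21.4 percentage points higher from compound 2 to compound 4 (beyond the scatter) gives the first reading of a single change, as no earlier pair differed in only one place. It shows that the position on a saturated chain carbon bound to an amide-type nitrogen and a carbonyl carbon is not indifferent: with a hydrogen atom in place of the group of 7 heavy atoms (4 carbon, 3 nitrogen; no ring), the read-out rises beyond the scatter, so that group is not needed for the effect seen here. Nothing measured on these compounds accounts for this step.

The compounds shown leave open whether a methyl group at this carbon would stay near compound 4 or return toward compound 2. They also leave open whether a shorter chain ending in an amine would do the same.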